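Pyridone ring substitution and rat hepatocyte clearance

The compounds below may be only part of what the source reports. "The series", "measured", "known", "first", "only" and "open" are said of these compounds alone.

Measured compounds:
compound 1 `CC(C)n1cc(-c2ccnc3[nH]c(C4CCN(CC(=O)N(C)C)CC4)cc23)cnc1=O`: 100 uL/min
compound 2 `CCn1cc(-c2ccnc3[nH]c(C4CCN(CC(=O)N(C)C)CC4)cc23)ccc1=O`: < 1 uL/min

In an ADME assay on cells (Hepatocyte, Rattus norvegicus) for metabolic stability (on this read-out lower numbers stand for slow clearance and higher numbers for fast clearance), compound 1 gives 100 uL/min. For compound 2 this assay reports only a limit, < 1 uL/min, so compound 2 stands at the limit rather than at a number (the limit of < 1 uL/min in this assay, at which 1 of the 2 values shown sits). Going by the values given here, the single measured step, an at least 100-fold lower number from compound 1 to compound 2 (2.00 log units; beyond the scatter), concerns a different change from the one leading to compound 3. Compound 3 `COc1cc(=O)n(C)cc1-c1ccnc2[nH]c(C3CCN(CC(=O)N(C)C)CC3)cc12` differs from compound 2 by a group of 10 heavy atoms (7 carbon, 1 nitrogen, 2 oxygen; one six-membered aromatic ring with 1 hetero atom) in place of a group of 9 heavy atoms (7 carbon, 1 nitrogen, 1 oxygen; one six-membered aromatic ring with 1 hetero atom), on an aromatic carbon. Among the compounds with values here, no measured step bears on this change, so the expected step, a number no lower from compound 2 to compound 3 (the limit leaves the size open), is none beyond the scatter. Compound 3 is therefore estimated at 1 uL/min, between 0.5 uL/min and 4 uL/min, with a real chance that again only a limit is reported.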

Compound 3, intrinsic clearance in a liver preparation (reported as CLH), per the amount of preparation that the assay uses in the Hepatocyte assay: < 1 uL/min
Compound 3 gave a limit, no number (the forecaster's own chance of this, stated with the estimate: 50%); the middle value lies on the limit itself.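

In the Hepatocyte assay this second swap of the ring again gives an at least 100-fold lower number from compound 1 to compound 3 (2.00 log units; beyond the scatter), so the low clearance holds with the larger group on this aromatic carbon, while the step between compound 2 and compound 3 cannot be read, as both values are limits of the assay. In a physicochemical assay for lipophilicity, using the shake flask method, measured as octanol-water partition, at pH 7.4 (on this read-out lower numbers stand for lower lipophilicity and higher numbers for higher lipophilicity), compound 2 gives 1.2 and compound 3 gives 0.7. The change therefore shifts the distribution coefficient, yet compound 3 still gives only a limit for clearance: the measured distribution coefficient of compound 2, 1.2, and of compound 3, 0.7, a number 0.50 log units lower (beyond the scatter)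

As far as these compounds go, how far compound 2 and compound 3 lie beyond that limit stays open. Also open, from the compounds shown here alone, is whether an ethoxy group, an amine or a nitrile on this aromatic carbon would keep clearance at the limit.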